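Amide in Place of an Active Ester at a Shared Core

The source may report more compounds than this note shows. Statements on the series, on what has been measured and on what is new or still open speak of the compounds shown alone.

The measured compounds:
compound 1 `CCN(CC)CCNC(=O)c1ccc(C(CC)(CC)c2ccc(OCC(O)C(C)(C)C)c(C)c2)n1CC` gives 6.54 nM
compound 2 `C#CCCOC(=O)c1ccc(C(CC)(CC)c2ccc(C#CC(O)(CC)CC)c(C)c2)n1CC` gives > 50 nM
compound 3 `CCn1c(C(=O)On2nnc3ccccc32)ccc1C(CC)(CC)c1ccc(C#CC(O)(CC)CC)c(C)c1` gives > 50 nM

In an assay on cells for agonist activity at vitamin D3 receptor (Homo sapiens), read by microscopy (on this read-out lower numbers stand for an effect already at smaller amounts and higher numbers for an effect only at larger amounts of compound), compound 1 gives 6.54 nM. For compound 2 the value of > 50 nM is a limit of this assay and not a number. For compound 3 the value of > 50 nM is likewise a limit, so compound 3 stands only at a limit, sharing this with one other value shown, as in the limit of > 50 nM in this assay, at which 2 of the 3 values shown sit. Going by the values given here, the one step between measured compounds, a step that the two limits leave unreadable from compound 2 to compound 3, is therefore unreadable in size.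

Compound 4 `CCn1c(C(=O)NCCC(=O)O)ccc1C(CC)(CC)c1ccc(C#CC(O)(CC)CC)c(C)c1` arises from compound 3 through (a group of 6 heavy atoms (3 carbon, 1 nitrogen, 2 oxygen; no ring) in place of a group of 10 heavy atoms (6 carbon, 3 nitrogen, 1 oxygen; one five-membered aromatic ring with 3 hetero atoms, one six-membered aromatic ring of carbon only), on a carbonyl carbon). No measured step bears directly on this change, since the only step shown is unreadable. Compound 1 carries an amide on the same carbonyl carbon and gives a number within the assay, so compound 4, also an amide, is expected to move toward readable potency, with the step estimated as an at least 1.6-fold lower number from compound 3 to compound 4 (0.22 log units; that floor lies within the scatter). The estimate for compound 4 is 30 nM, expected between 5 nM and 200 nM.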

Compound 4, half-maximal effective concentration: 293 nM
Compound 4: the middle estimate sits 9.8-fold (0.99 log units) below what was measured; measured number outside the range, above it.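

Going by these compounds alone, no step from compound 2 or from compound 3 to compound 4 can be read in this assay, as compound 2 and compound 3 both stand only at a limit: the limit of > 50 nM in this assay, at which 2 of the 4 values shown sit. The compounds shown leave open how large the effect of (2-carboxyethyl)amino on the carbonyl carbon is.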